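Replacing the 1-methyl-1H-indol-3-yl group of compound 2

The source may report more compounds than this note shows. Statements on the series, on what has been measured and on what is new or still open speak of the compounds shown alone.

Within the data shown here, in a functional assay on MCF7 cells (Homo sapiens) for inhibition, read by CCK-8 assay, with a stated time of 48 h (on this read-out lower numbers stand for stronger inhibition and higher numbers for weaker inhibition), compound 1 (`COc1cc(-c2ccnc3cc(-c4c[nH]c5ccccc45)nn23)cc(OC)c1OC`) gives 85 nM and compound 2 (`COc1cc(-c2ccnc3cc(-c4cn(C)c5ccccc45)nn23)cc(OC)c1OC`) gives 95 nM, so compound 2 stands level with its only measured neighbour. Compound 3 (`COc1cc(-c2ccnc3cc(-c4ccc(N(C)C)cc4)nn23)cc(OC)c1OC`) differs from compound 2 by a much larger change: 4-(dimethylamino)phenyl in place of 1-methyl-1H-indol-3-yl on an aromatic carbon. Put simply, 4-(dimethylamino)phenyl comes in place of 1-methyl-1H-indol-3-yl on an aromatic carbon.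

Among the measured compounds shown here, only one measured step bears on this, a 1.1-fold higher number from compound 1 to compound 2 (0.05 log units; within the scatter), which comes from methyl in place of hydrogen on an aromatic nitrogen. That small edit lies within the scatter, but it only alters the group that now leaves entirely. For the measured compounds named here, no measured compound shows what happens when that whole group is exchanged, so the evidence is thin. A moderate move towards a higher number in this assay, meaning weaker inhibition, is a cautious expectation, and no change at all remains possible. The expected size is a 2.3-fold higher number from compound 2 to compound 3 (0.36 log units; beyond the scatter). Compound 3 is estimated at 220 nM, with an expected range of 60 nM to 900 nM.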

Compound 3, half-maximal inhibitory concentration: 44 nM
For compound 3 the middle estimate is 5.0-fold (0.70 log units) above the measured one; the measured number lies below the stated range.
By their numbers in this assay, from the lowest: compounds 3, 1 and 2 (each within the scatter of the next, the first and the last beyond it).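

In this assay, the step from the fused indole group to a single ring gives a 2.2-fold lower number from compound 2 to compound 3 (0.33 log units; beyond the scatter), which shows that this aromatic carbon of the five-membered ring does not depend on the 1-methyl-1H-indol-3-yl group: 4-(dimethylamino)phenyl, with one six-membered aromatic ring of carbon only, is tolerated here and even gives a modest gain over compound 2. Against the group without the methyl, the same kind of exchange gives a 1.9-fold lower number from compound 1 to compound 3 (0.29 log units; within the scatter), so compound 3 cannot be ranked above compound 1, and the gain holds only relative to compound 2. Nothing measured here accounts for the difference between these groups.

The compounds shown leave open how much of the result belongs to the phenyl ring and how much to the dimethylamino group on it, a question that plain phenyl would help to answer. Nor do they show whether another group on that ring, such as methoxy or morpholine, would keep the number at this level or move it further.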